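Extending the side chain of an adenosine-based decarboxylase inhibitor

The compounds below may be only part of what the source reports. "The series", "measured", "known", "first", "only" and "open" are said of these compounds alone.

Measured compounds:
compound 1, `CNc1nc2c(N)ncnc2n1[C@@H]1O[C@H](CN(C)CCCCON)[C@@H](O)[C@H]1O`: 49 nM
compound 2, `Cc1nc2c(N)ncnc2n1[C@@H]1O[C@H](CN(C)CCN)[C@@H](O)[C@H]1O`: 88000 nM

In an assay on isolated protein for inhibition of S-adenosylmethionine decarboxylase proenzyme (Homo sapiens) (a higher number here means a weaker inhibitor, a lower number a stronger inhibitor), compound 2 has the higher of the two numbers, and its gap to compound 1 lies beyond the scatter. Compound 3, `Cc1nc2c(N)ncnc2n1[C@@H]1O[C@H](CN(C)CCCCON)[C@@H](O)[C@H]1O`, is not yet measured. Going from compound 2 to compound 3 the change is 2-(aminooxy)ethyl in place of amino on a saturated chain carbon, two bonds along the chain from an amine nitrogen. Compound 3 shares this longer chain with compound 1, whose core differs from it elsewhere. A large drop is expected, a 220-fold lower number from compound 2 to compound 3 (2.34 log units; beyond the scatter), because compound 1 with the same chain gives 49 nM. Compound 3 is estimated at 400 nM, within 40 nM to 4000 nM.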

Compound 3, half-maximal inhibitory concentration: 5 nM
Beside the measured number, compound 3's estimate is 80-fold (1.90 log units) above it, outside the stated range (below it).
By their numbers in this assay, from the lowest: compound 3; then compound 1; then compound 2.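

In this assay the change to 2-(aminooxy)ethyl in place of amino on a saturated chain carbon, two bonds along the chain from an amine nitrogen, gives an 18000-fold lower number from compound 2 to compound 3 (4.25 log units; beyond the scatter) with nothing else altered, so the chain change alone produces this gain. Methyl in place of methylamino on an aromatic carbon gives a 9.8-fold lower number from compound 1 to compound 3 (0.99 log units; beyond the scatter) with the chain held fixed, so that second place also counts. Still open, as far as these compounds go, is whether a longer chain, or a plain amine at its end, would keep this strength, or whether ethyl on the aromatic carbon would lower the number further. Nothing measured here explains either step.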